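Swapping amino for fluoro on a highly active compound

The source may report more compounds than this note shows. Statements on the series, on what has been measured and on what is new or still open speak of the compounds shown alone.

- compound 1 `COc1ccc(-c2c(-c3cc(Cl)c(OC)c(OC)c3)ncn2C)cc1F` gives > 10000 nM
- compound 2 `COc1ccc(-c2c(-c3cc(Br)c(OC)c(OC)c3)ncn2C)cc1N` gives 0.1 nM

Among the measured compounds shown here, in a functional assay on HL-60 cells (Homo sapiens) for cytotoxicity, read by MTT assay, with a stated time of 72 h (on this read-out higher numbers stand for weaker inhibition and lower numbers for stronger inhibition), compound 2 gives 0.1 nM, the only actual number among the values so far. The other reading is a limit of the assay, not a number. Compound 3 `COc1ccc(-c2c(-c3cc(Br)c(OC)c(OC)c3)ncn2C)cc1F` has not yet been measured. It departs from compound 2 in one place: fluoro in place of amino on an aromatic carbon. In compound 3 the fluoro group sits ortho to a methoxy group and meta to a large group. For the measured compounds named here, no measured pair of compounds isolates this change, so any expectation in this assay is indirect. It rests on compound 1, which carries fluoro in the same place and gives > 10000 nM, a limit of the assay. A very large upward step, towards much weaker inhibition and well beyond the scatter, is therefore expected: a 20000-fold higher number from compound 2 to compound 3 (4.30 log units; beyond the scatter). Compound 3 is estimated at 2000 nM, with an expected range of 100 nM to 10000 nM.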

Compound 3, half-maximal inhibitory concentration: 9700 nM
Compound 3: middle estimate off by 4.9-fold (0.69 log units), on the low side; measured number inside the range.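

Among the compounds shown here, the pair of compound 2 and compound 3 isolates this change for the first time. In this assay, fluoro in place of amino on an aromatic carbon, ortho to a methoxy group and meta to a large group, gives a 97000-fold higher number from compound 2 to compound 3 (4.99 log units; beyond the scatter), with the bromo group and the rest of the structure kept the same. With fluoro held in this place, bromo in place of chloro gives an at least 1.0-fold lower number from compound 1 to compound 3 (0.01 log units; that floor lies within the scatter), a floor that does not show how large that step really is.

On these data alone, how far that step runs stays open because the value of compound 1 is a limit of the assay: the limit of > 10000 nM in this assay, at which 1 of the 3 values shown sits. The compounds shown also leave open how a hydroxyl group, a methylamino group or an acetamido group would read at this position, and whether amino would keep its very low number with chloro in place of bromo.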